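Chain extension on the octanoyl ketone series

The source may hold more compounds than are shown below. What is called first, only, known or untested is meant among the compounds shown, and "the series" means these compounds.

Measured so far:
compound 1 `O=C(CCCCCCCCc1ccccc1)c1nc2ncccc2o1`: 3.63 nM
compound 2 `CCCCCCCC(=O)c1nc2ncccc2o1`: 631 nM

In an assay on HEK-293T cells for inhibition of diacylglycerol lipase-alpha (Homo sapiens), read by colorimetric assay (a higher number here means a weaker inhibitor, a lower number a stronger inhibitor), compound 2 gives the highest number of the two shown; its nearest neighbour is compound 1, and a 170-fold higher number from compound 1 to compound 2 (2.24 log units; beyond the scatter). Compound 3 `C=CCCCCCCCC(=O)c1nc2ncccc2o1` differs from compound 2 by vinyl in place of hydrogen on a saturated chain carbon, seven bonds along the chain from a carbonyl carbon. Among the compounds with values here, the only step that bears on this is the loss from compound 1 to compound 2, a large one in the same region of the chain; the vinyl restores part of what was removed. The expected move in this assay is therefore toward a lower number, an 11-fold lower number from compound 2 to compound 3 (1.02 log units; beyond the scatter), smaller than the measured step. Compound 3 is estimated at 60 nM, range 15 nM to 250 nM.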

Compound 3, half-maximal inhibitory concentration: 550 nM
Compound 3: middle estimate off by 9.2-fold (0.96 log units), on the low side; the whole stated range lies below it.
By their numbers in this assay, from the lowest: compound 1; then compounds 3 and 2 (each within the scatter of the next).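

In this assay, vinyl in place of hydrogen at this place gives a 1.1-fold lower number from compound 2 to compound 3 (0.06 log units; within the scatter), so the added alkene does not separate compound 3 from compound 2. Vinyl does not stand in for benzyl here, with a 150-fold higher number from compound 1 to compound 3 (2.18 log units; beyond the scatter); among the groups shown at this place, only benzyl goes with the low number. No supporting data bear on why these groups differ. Open, on these data alone, is whether an ethyl group, a cyclohexyl ring or a longer chain at this place would read like compound 3 or like compound 1.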